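A few compounds are considered here, and "the series" means these few. Any claim that something is new, unique, unknown or untested is made for them only; others in the source may bear on it.

Compound 3 `O=c1[nH]/c(=N\OCCCc2ccsc2)ccn1[C@@H]1O[C@H](COP(=O)(O)OP(=O)(O)OP(=O)(O)O)[C@@H](O)[C@H]1O` gives the lowest number of the three compounds measured in a functional assay on 1321-N1 cells for agonist activity at P2Y purinoceptor 4 (Homo sapiens), read by scintillation counting and inositol phosphate accumulation; on this read-out higher numbers stand for an effect only at larger amounts of compound and lower numbers for an effect already at smaller amounts: compound 3 gives 20 nM. Its nearest neighbour is compound 2 `O=c1[nH]/c(=N\OCCCc2ccc(Br)cc2)ccn1[C@@H]1O[C@H](COP(=O)(O)OP(=O)(O)OP(=O)(O)O)[C@@H](O)[C@H]1O`, which in this assay gives 141 nM, and the furthest is compound 1 `O=C(O)CCCO/N=c1/ccn([C@@H]2O[C@H](COP(=O)(O)OP(=O)(O)OP(=O)(O)O)[C@@H](O)[C@H]2O)c(=O)[nH]1`, which gives 470 nM. The steps between them are all beyond the scatter: a 3.3-fold lower number from compound 1 to compound 2 (0.52 log units; beyond the scatter), a 24-fold lower number from compound 1 to compound 3 (1.37 log units; beyond the scatter) and a 7.1-fold lower number from compound 2 to compound 3 (0.85 log units; beyond the scatter).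

Compound 4 `O=c1[nH]/c(=N\OCCCc2ccc3ccccc3c2)ccn1[C@@H]1O[C@H](COP(=O)(O)OP(=O)(O)OP(=O)(O)O)[C@@H](O)[C@H]1O` differs from compound 3 in one place: naphthalen-2-yl in place of thiophen-3-yl on a saturated chain carbon, three bonds along the chain from an oxygen. All three measured steps bear on this change, since each one swaps the group on the same saturated chain carbon. They show that the identity of the group at this position moves the number substantially, and that the two aromatic groups already tried do not behave alike. Within the data shown here, compound 3 carries the group that gives the lowest number so far, so a further exchange is expected to give a modest step back toward higher numbers rather than a further fall; the estimate for the step is a 3.0-fold higher number from compound 3 to compound 4 (0.48 log units; beyond the scatter). Compound 4 is therefore expected to give about 60 nM in this assay, with a range from 15 nM to 250 nM.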

Compound 4, half-maximal effective concentration: 128 nM
The estimate for compound 4 lay 2.1-fold (0.33 log units) below the measured number; the range from low to high includes it.
By their numbers in this assay, from the lowest: compound 3; then compounds 4 and 2 (each within the scatter of the next); then compound 1.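

With the two-ring naphthalen-2-yl in place of the single five-membered thiophen-3-yl, this assay gives a 6.4-fold higher number from compound 3 to compound 4 (0.81 log units; beyond the scatter), so the low number of compound 3 does not carry over to this larger aromatic group. The step of a 1.1-fold lower number from compound 2 to compound 4 (0.04 log units; within the scatter) lies within the scatter, which leaves thiophen-3-yl alone at the low end among the three aromatic groups, while 4-bromophenyl and naphthalen-2-yl cannot be told apart here even though they differ in ring count. The step of a 3.7-fold lower number from compound 1 to compound 4 (0.56 log units; beyond the scatter) shows that naphthalen-2-yl, like the other two aromatic groups, gives a lower number than carboxy on this saturated chain carbon, but nothing measured for these compounds explains the differences among the groups.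

Going by these compounds, it remains open whether the low number of compound 3 goes with the sulfur atom or with the five-membered ring, a question that a furan-3-yl, a thiophen-2-yl or an unsubstituted phenyl on the same carbon would address. Also open, on these data alone, is how a shorter or longer chain carrying thiophen-3-yl would read in this assay.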